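The compounds below may be only part of what the source reports. "The series", "measured", "known", "first", "only" and "open" are said of these compounds alone.

Compound 1 `NS(=O)(=O)NCC1CCN(c2cc(-c3ccc(Cl)cc3)ncn2)CC1` and compound 3 `NS(=O)(=O)NCCC1CCN(c2cc(-c3ccc(Cl)cc3)ncn2)CC1` share one core and differ in a single place: (sulfamoylamino)methyl in place of sulfamoylamino on a saturated chain carbon bound to a saturated ring carbon. In a functional assay on MCF7 cells (Homo sapiens) for antiproliferative activity, read by sulforhodamine B assay, with a stated time of 48 h (on this read-out lower numbers stand for stronger inhibition of growth and higher numbers for weaker inhibition of growth), compound 1 gives 25500 nM, while compound 3 gives 19700 nM, so the step is a 1.3-fold lower number from compound 1 to compound 3 (0.11 log units; within the scatter). Compound 2 `NS(=O)(=O)NCC1CCN(c2cc(-c3cccc4ccccc34)ncn2)CC1` carries a different core; the difference between the two cores is not broken down here. In this assay compound 2 gives 12100 nM. Compound 4 `NS(=O)(=O)NCCC1CCN(c2cc(-c3cccc4ccccc34)ncn2)CC1` stands to compound 2 as compound 3 stands to compound 1, through ((sulfamoylamino)methyl in place of sulfamoylamino on a saturated chain carbon bound to a saturated ring carbon), at the same place on the chain. For compound 4 the step is expected to be a 1.3-fold lower number from compound 2 to compound 4 (0.11 log units; within the scatter), because the earlier step of a 1.3-fold lower number from compound 1 to compound 3 (0.11 log units; within the scatter) was small. Compound 4 is therefore estimated at 9500 nM, expected to lie between 4000 nM and 22000 nM.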

Compound 4, concentration for 50% growth inhibition: 5900 nM
Compound 4: middle estimate off by 1.6-fold (0.21 log units), on the high side; the range from low to high includes it.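

Moving from the (sulfamoylamino)methyl to the 2-(sulfamoylamino)ethyl chain on the core of compound 2 gives a 2.1-fold lower number from compound 2 to compound 4 (0.31 log units; beyond the scatter). Set beside the same change on the core of compound 1, the two steps do not differ by more than repeated measurements would: the same change on two cores in this assay, a 1.3-fold lower number (0.11 log units; within the scatter) from compound 1 to compound 3 and a 2.1-fold lower number (0.31 log units; beyond the scatter) from compound 2 to compound 4, 1.6-fold (0.20 log units) apart, within the scatter of two such steps

So the change carries over between these two cores with no measurable difference in size, but two pairs say nothing about any other core, and only the step on the core of compound 2 lies beyond the scatter. The compounds shown leave open how a longer chain would read in this assay. They also leave open what an amine or a carboxylic acid in place of the sulfamoylamino group would give.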